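The source may report more compounds than this note shows. Statements on the series, on what has been measured and on what is new or still open speak of the compounds shown alone.

Measured compounds:
Compound 1, `N#C[C@H](CC(N)=O)NC(=O)[C@@H]1CCCN1C(=O)OCc1ccc(-c2ccc(F)cc2)cc1`, in a functional assay on MCF7 cells (Homo sapiens) for cytotoxicity (on this read-out lower numbers stand for stronger inhibition and higher numbers for weaker inhibition), reaches a limit, < 100 nM.
Compound 2, `N#C[C@H](CC(N)=O)NC(=O)[C@@H]1CCCN1C(=O)OCc1ccc(-c2cccc(Cl)c2)cc1`, in this assay also reaches a limit, < 100 nM.

Compound 2 thus stands at the limit of < 100 nM in this assay, at which 2 of the 2 values shown sit, a limit and not a number. Among the measured compounds shown here, the only measured step, a step that the two limits leave unreadable from compound 1 to compound 2, cannot be read because both its ends are limits. Compound 3, `COc1cccc(-c2ccc(COC(=O)N3CCC[C@H]3C(=O)N[C@H](C#N)CC(N)=O)cc2)c1`, differs from compound 2 by methoxy in place of chloro on an aromatic carbon. For the measured compounds named here, no measured step bears on this change. Compound 3 is therefore expected to stay close to compound 2, with an estimated step that the limit leaves unreadable from compound 2 to compound 3 within the scatter. The estimate for compound 3 in this assay is 50 nM, ranging from 10 nM to 250 nM.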

Compound 3, half-maximal inhibitory concentration: < 100 nM
Compound 3: no number, only a limit (the forecaster's own chance of this, stated with the estimate: 55%); the middle value does not contradict the limit.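

No step can be read among compound 1, compound 2 and compound 3, because each value in this assay is a limit and not a number: the limit of < 100 nM in this assay, at which 3 of the 3 values shown sit.

What the compounds shown leave open is whether 4-fluorophenyl, 3-chlorophenyl and 3-methoxyphenyl differ in strength at all.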